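Positional isomer of compound 3: working notes

The compounds below may be only part of what the source reports. "The series", "measured", "known", "first", "only" and "open" are said of these compounds alone.

Measured so far in this series:
compound 1 `CC#CCn1c(N2CCC[C@@H](N)C2)nc2c1c(=O)n(Cc1cc(C#N)ccc1C(=O)O)c(=O)n2C` — > 100000 nM
compound 2 `CC#CCn1c(N2CCC[C@@H](N)C2)nc2c1c(=O)n(Cc1ccccc1C(=O)O)c(=O)n2C` — > 100000 nM
compound 3 `CC#CCn1c(N2CCC[C@@H](N)C2)nc2c1c(=O)n(Cc1cc(Cl)ccc1C(=O)OC)c(=O)n2C` — > 100000 nM

All three values in an ADME assay on isolated protein for inhibition of Dipeptidyl peptidase 9 (Homo sapiens), with stated times of 15 min, 60 s and 20 min (on this read-out higher numbers stand for weaker inhibition and lower numbers for stronger inhibition), are limits of the assay and not numbers. For compound 1 the recorded value is a limit. For compound 2 the recorded value is a limit. For compound 3 the recorded value is a limit as well, so compound 3 stands where the other two stand, with no number to set it apart from them. Among the measured compounds shown here, the measured steps a step that the two limits leave unreadable from compound 1 to compound 2, a step that the two limits leave unreadable from compound 1 to compound 3 and a step that the two limits leave unreadable from compound 2 to compound 3 are accordingly of unreadable size; the only evidence on them is the limit of > 100000 nM in this assay, at which 3 of the 3 values shown sit.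

Compound 4 `CC#CCn1c(N2CCC[C@@H](N)C2)nc2c1c(=O)n(Cc1ccc(Cl)cc1C(=O)OC)c(=O)n2C` differs from compound 3 by 4-chloro-2-(methoxycarbonyl)phenyl in place of 5-chloro-2-(methoxycarbonyl)phenyl on a saturated chain carbon bound to an aromatic nitrogen. For the measured compounds named here, none of the measured steps concerns a change of this kind, so no step gives a readable size for it in this assay. Going by the values given here, the only anchor is that compound 3 sits at the limit, and the change keeps every group and merely moves one of them.

On that basis compound 4 is expected to remain at the limit rather than to yield a number, with the step that the limit leaves unreadable from compound 3 to compound 4 expected to be nothing beyond the scatter. For compound 4 the estimate is 150000 nM, with a range from 50000 nM to 500000 nM.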

Compound 4, half-maximal inhibitory concentration: > 100000 nM
Compound 4: only a limit was reported (the forecaster's own chance of this, stated with the estimate: 85%); the middle value is on the limit's open side.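

In this assay compound 4 gives > 100000 nM as a limit of the assay and not a number. No new step can be read between compound 4 and compound 1, compound 2 or compound 3, and the evidence is only this: the limit of > 100000 nM in this assay, at which 4 of the 4 values shown sit.

The compounds shown leave open whether 4-chloro-2-(methoxycarbonyl)phenyl and 5-chloro-2-(methoxycarbonyl)phenyl differ at all in this assay.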